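Working notes: 4-methoxyphenyl to 4-ethoxyphenyl in the series

The compounds below may be only part of what the source reports. "The series", "measured", "known", "first", "only" and "open" are said of these compounds alone.

Measured in a functional assay on A549 cells (Homo sapiens) for antiproliferative activity, read by MTT assay, with a stated time of 72 h; on this read-out lower numbers stand for stronger inhibition and higher numbers for weaker inhibition:
- compound 1 `CNc1nc(-c2cc(OC)c(OC)c(OC)c2)c(-c2ccc(C)cc2)s1`, 125 nM
- compound 2 `CNc1nc(-c2cc(OC)c(OC)c(OC)c2)c(-c2ccc(C(F)(F)F)cc2)s1`, 4570 nM
- compound 3 `CNc1nc(-c2cc(OC)c(OC)c(OC)c2)c(-c2ccc(OC)cc2)s1`, 138 nM

Compound 3 stands level with compound 1, the gap being a 1.1-fold higher number from compound 1 to compound 3 (0.04 log units; within the scatter). Compound 2 lies far off at the other end of the range, and the gap there is a 33-fold lower number from compound 2 to compound 3 (1.52 log units; beyond the scatter).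

The next compound is compound 4 `CCOc1ccc(-c2sc(NC)nc2-c2cc(OC)c(OC)c(OC)c2)cc1`, which differs from compound 3 by one change: methyl in place of hydrogen on a saturated chain carbon bound to an oxygen on an aromatic ring. This turns methoxy into ethoxy, or 4-methoxyphenyl into 4-ethoxyphenyl.

Among the measured compounds shown here, no measured step makes this change itself, so the evidence is indirect. The closest step is the one that introduced methoxy in place of methyl, a 1.1-fold higher number from compound 1 to compound 3 (0.04 log units; within the scatter), which stays small. Trifluoromethyl in place of methyl gave a 37-fold higher number from compound 1 to compound 2 (1.56 log units; beyond the scatter), so a single group swap on this ring can move the number a long way, and the range must stay wide.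

A small step towards a higher number is expected, probably not beyond the scatter. The estimated step is a 1.6-fold higher number from compound 3 to compound 4 (0.20 log units; within the scatter). In this assay the expected value of compound 4 is 220 nM, within an estimated range of 60 nM to 800 nM.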

Compound 4, half-maximal inhibitory concentration: 38.6 nM
Estimate against measurement, compound 4: 5.7-fold (0.76 log units) above; measured number outside the range, below it.
By their numbers in this assay, from the lowest: compound 4; then compounds 1 and 3 (each within the scatter of the next); then compound 2.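

In this assay, adding one methyl to the methoxy group gives a 3.6-fold lower number from compound 3 to compound 4 (0.55 log units; beyond the scatter), so a change of a single carbon on this chain is enough to move the number beyond the scatter, although the swap between methyl and methoxy on the same aromatic carbon had not. Ethoxy also separates from the methyl group of compound 1 (a 3.2-fold lower number from compound 1 to compound 4 (0.51 log units; beyond the scatter)) and so takes the number below the level shared by compound 1 and compound 3, making compound 4 the most potent of the four in this read-out, while the distance to the trifluoromethyl group of compound 2 widens to a 120-fold lower number from compound 2 to compound 4 (2.07 log units; beyond the scatter). Nothing at hand gives a reason for this drop.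

On these data alone, with only methoxy and ethoxy as chains on this oxygen, two points do not make a trend, and it remains open whether a longer chain such as propoxy or butoxy, or a branched one such as isopropoxy, would lower the number further or reverse the step. Also open, as far as these compounds go, is how a hydroxyl or an amine on this aromatic carbon would compare with ethoxy.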